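Ring-nitrogen substituent series: expectation for compound 3

The source may report more compounds than this note shows. Statements on the series, on what has been measured and on what is new or still open speak of the compounds shown alone.

Measured compounds in this assay:
compound 1 `CCC(C)n1cnc2c(NCc3ccc(C(=O)Nc4ccccc4N)cc3)nc(Cl)nc21`: 74.6%
compound 2 `CC(C)n1cnc2c(NCc3ccc(C(=O)Nc4ccccc4N)cc3)nc(Cl)nc21`: 73.2%

In a functional assay on HCT-116 cells (Homo sapiens) for antiproliferative activity, read by CCK-8 assay, with a stated time of 72 h, tested at 2 uM (on this read-out lower numbers stand for a weaker effect and higher numbers for a stronger effect at the one concentration tested), compound 1 gives 74.6% and compound 2 gives 73.2%. Compound 2 holds the lowest of the two numbers, but its nearest neighbour, compound 1, lies within the scatter. Within the data shown here, the one measured step, a number 1.4 percentage points lower from compound 1 to compound 2 (within the scatter), changes the same substituent on the aromatic nitrogen and stays within the scatter.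

Compound 3 `Nc1ccccc1NC(=O)c1ccc(CNc2nc(Cl)nc3c2ncn3C2CCCC2)cc1` differs from compound 2 by cyclopentyl in place of isopropyl on an aromatic nitrogen. Among the measured compounds shown here, because the only related step of a number 1.4 percentage points lower from compound 1 to compound 2 (within the scatter) was within the scatter, no step beyond the scatter is expected here. Compound 3 is estimated at 74%, ranging from 62% to 84%. The expected step is a number 0.8 percentage points higher from compound 2 to compound 3 (within the scatter).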

Compound 3, a percentage reported as inhibition, at one concentration (the size of the read-out at that concentration, not a potency): 75.6%
Beside the measured number, compound 3's estimate is 1.6 percentage points below it; the measured number falls inside the stated range.
By their numbers in this assay, from the lowest: compounds 2, 1 and 3 (each within the scatter of the next).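

In this assay, among these compounds, a ring now stands on the aromatic nitrogen, where the earlier compounds carried only open chains. The result is a number 2.4 percentage points higher from compound 2 to compound 3 (within the scatter) and a number 1 percentage points higher from compound 1 to compound 3 (within the scatter), and neither step separates cyclopentyl from isopropyl or sec-butyl at this place. No measurement here bears on why these groups read alike.

From the compounds shown here alone, whether a cyclopentyl carrying an amine or a carboxylic acid, or a longer chain, would keep this level on the aromatic nitrogen remains open. These numbers show the size of the effect at the one concentration tested, and at that concentration none of these compounds separates as having a stronger or weaker effect.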